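Ethoxy Added to a Series With Little Spread

The source may report more compounds than this note shows. Statements on the series, on what has been measured and on what is new or still open speak of the compounds shown alone.

In a functional assay, with a stated time of 10 min (a higher number here means a weaker inhibitor, a lower number a stronger inhibitor), compound 1 `O=c1cc(/C=C/c2ccccc2)occ1O` gives 2250 nM. Two close relatives sit nearby: compound 2 `O=c1cc(/C=C/c2ccc(Cl)cc2)occ1O` gives 1950 nM, and compound 3 `CN(C)c1ccc(/C=C/c2cc(=O)c(O)co2)cc1` gives 3050 nM. Compound 1 therefore stands level with both, since every step among these three lies within the scatter of repeated measurements.

The next compound to be tested is compound 4 `CCOc1ccc(/C=C/c2cc(=O)c(O)co2)cc1`. Its difference from compound 1 is ethoxy in place of hydrogen on an aromatic carbon, which in words is ethoxy in place of hydrogen on an aromatic carbon, para to a large group.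

Going by the values given here, two measured steps bear on this change, as each also replaces a hydrogen on an aromatic carbon. Chloro gives a 1.2-fold lower number from compound 1 to compound 2 (0.06 log units; within the scatter), and dimethylamino gives a 1.4-fold higher number from compound 1 to compound 3 (0.13 log units; within the scatter). Neither step goes beyond the scatter, so ethoxy is not expected to shift the number beyond the scatter in this assay either.

The expected step is a 1.1-fold higher number from compound 1 to compound 4 (0.05 log units; within the scatter), which is no real change. For compound 4, the estimated value is 2500 nM, with an expected range of 1300 nM to 4500 nM.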

Compound 4, half-maximal inhibitory concentration: 4210 nM
The estimate for compound 4 lay 1.7-fold (0.23 log units) below the measured number, within the range that was stated.
By their numbers in this assay, from the lowest: compounds 2, 1, 3 and 4 (each within the scatter of the next, the first and the last beyond it).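

Ethoxy, para to a large group, is the first group in this series to give a step beyond the scatter in this assay, although only against chloro and only modestly, with a 2.2-fold higher number from compound 2 to compound 4 (0.33 log units; beyond the scatter). Replacing hydrogen with ethoxy, which adds a chain of 3 heavy atoms, stays within the scatter, with a 1.9-fold higher number from compound 1 to compound 4 (0.27 log units; within the scatter), and so does exchanging dimethylamino for ethoxy, with a 1.4-fold higher number from compound 3 to compound 4 (0.14 log units; within the scatter). The change at this position is therefore tolerated, with one pair of groups only just told apart, and nothing measured here explains that gap.

The compounds shown leave open whether a carboxylic acid or a longer chain such as butoxy at this position would move the number beyond the scatter from compound 1. They also leave open what ethoxy would do elsewhere on the same aromatic ring.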